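Furan-2-yl to 1-benzofuran-2-yl: working notes

The compounds below may be only part of what the source reports. "The series", "measured", "known", "first", "only" and "open" are said of these compounds alone.

Values in an ADME assay on MRC5 cells (Homo sapiens), read by MTT assay, with a stated time of 72 h (on this read-out lower numbers stand for stronger inhibition and higher numbers for weaker inhibition), all of them limits:
- compound 1 `CN(C)c1ncnc2c1c(-c1ccsc1)cn2[C@@H]1O[C@H](CO)[C@@H](O)[C@H]1O`: > 100000 nM
- compound 2 `Cc1ncnc2c1c(-c1ccsc1)cn2[C@@H]1O[C@H](CO)[C@@H](O)[C@H]1O`: > 100000 nM
- compound 3 `Nc1nc(N)c2c(-c3ccco3)cn([C@@H]3O[C@H](CO)[C@@H](O)[C@H]3O)c2n1`: > 100000 nM

In this assay, compound 3 gives > 100000 nM, which is a limit and not a number. The other two values are limits as well, and the whole set stands at one point: the limit of > 100000 nM in this assay, at which 3 of the 3 values shown sit.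

Compound 4 `Nc1nc(N)c2c(-c3cc4ccccc4o3)cn([C@@H]3O[C@H](CO)[C@@H](O)[C@H]3O)c2n1` differs from compound 3 by one exchange: 1-benzofuran-2-yl in place of furan-2-yl on an aromatic carbon.

Within the data shown here, only one measured step exists, a step that the two limits leave unreadable from compound 1 to compound 2. It involves a different group and gives no size, so nothing measured sizes the present exchange. With no number as a starting point, a readable change can only run toward lower values, meaning stronger inhibition. Compound 4 is therefore expected to stay at or close to the limit, with a reported limit somewhat more likely than a number.

The expected change is an at least 1.2-fold lower number from compound 3 to compound 4 (0.09 log units; that floor lies within the scatter), and this estimate is loose. Compound 4 is estimated at 80000 nM, with an expected range of 20000 nM to 100000 nM.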

Compound 4, half-maximal inhibitory concentration: 78500 nM
Beside the measured number, compound 4's estimate is 1.0-fold (0.01 log units) above it, within the range that was stated.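

In this assay, among these compounds, compound 4 gives 78500 nM, the first number in the set rather than a limit, so this aromatic carbon of the five-membered ring with 1 nitrogen can carry a group that brings the read-out into measurable range. On these data alone, the exchange gives an at least 1.2-fold lower number from compound 3 to compound 4 (0.10 log units; that floor lies within the scatter), so its size has only a floor and its true extent stays unknown. The steps that end in a limit on both sides cannot be read, and the set still sits largely at one point: the limit of > 100000 nM in this assay, at which 3 of the 4 values shown sit.

As far as these compounds go, how a phenyl or a 1-benzothiophen-2-yl group would read at this place remains open, and so does whether the added six-membered aromatic ring alone accounts for the number. Also open, from the compounds shown here alone, is whether 1-benzofuran-2-yl gives a number on the core of compound 1.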